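The source may report more compounds than this note shows. Statements on the series, on what has been measured and on what is new or still open speak of the compounds shown alone.

Compound 1 `O=C(O)c1csc([C@H]2CC[C@@H]3[C@@H](COc4ccc(F)cc4)[C@H](O)C[C@@H]3O2)n1`: in an assay on HEK293 cells for agonist activity at prostaglandin E2 receptor EP2 subtype (Homo sapiens), read by a beta-galactosidase reporter and beta-arrestin recruitment, with a stated time of 90 min (on this read-out higher numbers stand for an effect only at larger amounts of compound and lower numbers for an effect already at smaller amounts), compound 1 gives > 10000 nM, which is a limit of the assay and not a number.
Compound 2 `O=C(O)c1csc([C@H]2CC[C@@H]3[C@@H](COc4ccccc4F)[C@H](O)C[C@@H]3O2)n1`: in this assay compound 2 gives > 10000 nM, again a limit of the assay.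
Compound 3 `O=C(O)c1csc([C@H]2CC[C@@H]3[C@@H](COc4cccc(Cl)c4)[C@H](O)C[C@@H]3O2)n1`: in this assay compound 3 gives > 10000 nM, also a limit of the assay.

Compound 3 therefore stands nowhere that can be told apart from the other two: all three values sit at the same limit, and none is a number. The three measured compounds differ from one another only in the aryl group on an oxygen on a saturated carbon, and the steps a step that the two limits leave unreadable from compound 1 to compound 2, a step that the two limits leave unreadable from compound 1 to compound 3 and a step that the two limits leave unreadable from compound 2 to compound 3 are each unreadable because of the limit of > 10000 nM in this assay, at which 3 of the 3 values shown sit.

Compound 4 `O=C(O)c1csc([C@H]2CC[C@@H]3[C@@H](CCCOc4ccccc4)[C@H](O)C[C@@H]3O2)n1` differs from compound 3 in one place: 2-phenoxyethyl in place of 3-chlorophenoxy on a saturated chain carbon bound to a saturated ring carbon. For the measured compounds named here, none of the measured steps reads on this change, since every one of them is hidden by the limit, so no size and no direction can be drawn from them. Going by the values given here, what can be said is that nothing among the measured compounds has yet left the limit. Compound 4 is accordingly expected to give about 8000 nM, within a wide range from 800 nM to 30000 nM, the expected step being an at least 1.2-fold lower number from compound 3 to compound 4 (0.09 log units; that floor lies within the scatter), with a real chance that only a limit is reported again.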

Compound 4, half-maximal effective concentration: > 10000 nM
Compound 4 was reported as a limit (the forecaster's own chance of this, stated with the estimate: 60%); middle value at least 1.2-fold (0.09 log units) from the limit.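

Compound 4 adds no readable step: its result is again only a limit of the assay, so its steps from compound 1, compound 2 and compound 3 cannot be read, because every value shown is that same limit: the limit of > 10000 nM in this assay, at which 4 of the 4 values shown sit.

The compounds shown leave open whether any of these groups on the shared core gives a measurable value in this assay, and how large any of these changes is.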